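A few compounds are considered here, and "the series" means these few. Any claim that something is new, unique, unknown or untested is made for them only; others in the source may bear on it.

Measured compounds in an ADME assay on the whole organism with Oryza sativa as the target, tested at 0.1 uM; on this read-out higher numbers stand for a weaker effect at the one concentration tested and lower numbers for a stronger effect:
- compound 1 `C[C@@H](NC(=O)Nc1ccccc1Cl)c1ccccc1`: 101%
- compound 2 `C[C@@H](NC(=O)Nc1cccc(Cl)c1)c1ccccc1`: 97%

Compound 2 stands alongside compound 1 in this assay; the two values lie within the usual scatter of each other, so no difference between them can be read from these numbers. Both sit near the level of no effect at the single concentration tested.

Compound 3 `C[C@@H](NC(=O)Nc1cccc(Cl)c1Cl)c1ccccc1` is not yet measured. It differs from compound 2 by chloro in place of hydrogen on an aromatic carbon. With both measured compounds at the no-effect level, no step beyond the scatter is expected in this assay. The expected step of a number 1 percentage points higher from compound 2 to compound 3 (within the scatter) reflects this. Compound 3 is estimated at 98%, range 85% to 106%.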

Compound 3, a percentage reported as activity, at one concentration (the size of the read-out at that concentration, not a potency): 100%
Compound 3: middle estimate off by 2 percentage points, on the low side, within the range that was stated.
By their numbers in this assay, from the lowest: compounds 2, 3 and 1 (each within the scatter of the next).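

In this assay chloro in place of hydrogen on an aromatic carbon, ortho to a chloro group, gives a number 3 percentage points higher from compound 2 to compound 3 (within the scatter) and also a number 1 percentage points lower from compound 1 to compound 3 (within the scatter) as the second step. A second chloro on the ring therefore leaves no readable mark from either starting point, which the two compounds with one chloro could not show. Nothing on hand explains this flat result.

Still open, as far as these compounds go, is whether any other group here moves the read-out from the no-effect level. An amine or a carboxylic acid in place of this chloro would be such a case.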